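A few compounds are considered here, and "the series" means these few. Any claim that something is new, unique, unknown or untested is made for them only; others in the source may bear on it.

Working notes on the series. In a functional assay on HeLa cells (Homo sapiens) for inhibition, read by MTT assay, with a stated time of 24 h (a higher number here means a weaker inhibitor, a lower number a stronger inhibitor), compound 1 `CCOC(=O)C1=Cc2ccccc2OC1(OCc1cn(CC(=O)NC2CCCCC2)nn1)C(F)(F)F` gives 11400 nM. Compound 2 `CCCCCCCCn1cc(COC2(C(F)(F)F)Oc3ccccc3C=C2C(=O)OCC)nn1` returns in this assay only a limit of the assay, > 150000 nM. Compound 3 `CCOC(=O)C1=Cc2ccccc2OC1(OCc1cn(CC(=O)Nc2ccc(OC)cc2)nn1)C(F)(F)F` gives 31900 nM in this assay, the higher of the two numbers shown; its nearest neighbour is compound 1, and the step between them is a 2.8-fold higher number from compound 1 to compound 3 (0.45 log units; beyond the scatter), a swap on the amide-type nitrogen. Compound 4 `CCOC(=O)C1=Cc2ccccc2OC1(OCc1cn(CC(=O)Nc2ccccc2F)nn1)C(F)(F)F` differs from compound 3 by 2-fluorophenyl in place of 4-methoxyphenyl on an amide-type nitrogen. Among the measured compounds shown here, the one measured step at this nitrogen, a 2.8-fold higher number from compound 1 to compound 3 (0.45 log units; beyond the scatter), was modest, and the present exchange of one aryl group for another is a smaller alteration than that one, so the expected step of a 1.1-fold lower number from compound 3 to compound 4 (0.06 log units; within the scatter) is none beyond the scatter, direction open. Compound 4 is therefore estimated at 28000 nM, between 11000 nM and 75000 nM.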

Compound 4, half-maximal inhibitory concentration: 49900 nM
Compound 4: the middle estimate sits 1.8-fold (0.25 log units) below what was measured; low and high end bracket the measured number.
By their numbers in this assay, from the lowest: compound 1; then compounds 3 and 4 (each within the scatter of the next). At a limit, above all of these: compound 2.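

In this assay, a 1.6-fold higher number from compound 3 to compound 4 (0.19 log units; within the scatter), so on the amide-type nitrogen this exchange of 2-fluorophenyl for 4-methoxyphenyl separates the two aryl groups by no more than the scatter. Cyclohexyl now stands apart from a second aryl group, with a 4.4-fold higher number from compound 1 to compound 4 (0.64 log units; beyond the scatter). The step of an at least 3.0-fold lower number from compound 2 to compound 4 (0.47 log units; beyond the scatter) is only a bound, as compound 2 gives a limit of the assay: the limit of > 150000 nM in this assay, at which 1 of the 4 values shown sits.

Still open, as far as these compounds go, is whether the gap between cyclohexyl and the two aryl groups holds for a benzyl or cyclopentyl group on this nitrogen.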